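Urea series: methoxy in place of bromo on the aryl ring

The source may report more compounds than this note shows. Statements on the series, on what has been measured and on what is new or still open speak of the compounds shown alone.

Values in an assay for binding affinity to receptor-interacting serine/threonine-protein kinase 3 (Homo sapiens), read by KINOMEscan and polymerase chain reaction, with a stated time of 1 h; on this read-out lower numbers stand for tighter binding and higher numbers for weaker binding:
Compound 1 `O=C(CCc1cccc(C(F)(F)F)c1)Nc1cc(Oc2ccc3nc(NC(=O)C4CC4)sc3c2)ccc1F` gives 790 nM.
Compound 2 `Cc1cccc(NC(=O)Nc2cc(Oc3ccc4nc(NC(=O)C5CC5)sc4c3)ccc2F)c1` gives 93 nM.
Compound 3 `O=C(Nc1cccc(Br)c1)Nc1cc(Oc2ccc3nc(NC(=O)C4CC4)sc3c2)ccc1F` gives 81 nM.

Compound 3 has the lowest number of the three, but only the gap to compound 1 is meaningful: a 9.8-fold lower number from compound 1 to compound 3 (0.99 log units; beyond the scatter). Against compound 2 the two values lie within the scatter, a 1.1-fold lower number from compound 2 to compound 3 (0.06 log units; within the scatter), so no order between compound 2 and compound 3 can be read. Of the same size is the parallel step an 8.5-fold lower number from compound 1 to compound 2 (0.93 log units; beyond the scatter).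

Compound 4 `COc1cccc(NC(=O)Nc2cc(Oc3ccc4nc(NC(=O)C5CC5)sc4c3)ccc2F)c1` differs from compound 3 in one place: methoxy in place of bromo on an aromatic carbon. Among the measured compounds shown here, the only measured step that exchanges one substituent on this ring for another is that from compound 2 to compound 3, where methyl and bromo gave values within the scatter. The two larger steps, both from compound 1, concern the group on the carbonyl carbon and say nothing about this ring substituent. Compound 4 is therefore expected to stay close to compound 3, with the step of a 1.4-fold higher number from compound 3 to compound 4 (0.13 log units; within the scatter) expected to remain within the scatter. The estimate for compound 4 in this assay is 110 nM, with a range from 45 nM to 270 nM.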

Compound 4, dissociation constant: 69 nM
The estimate for compound 4 lay 1.6-fold (0.20 log units) above the measured number; the range from low to high includes it.
By their numbers in this assay, from the lowest: compounds 4, 3 and 2 (each within the scatter of the next); then compound 1.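

Methoxy on the aryl ring of the urea series reads the same as bromo in this assay, with a 1.2-fold lower number from compound 3 to compound 4 (0.07 log units; within the scatter) and no order to be drawn, and the same holds against methyl, with a 1.3-fold lower number from compound 2 to compound 4 (0.13 log units; within the scatter). Three substituents at this ring position now give values within the scatter of one another, even though methoxy brings a hydrogen-bond acceptor and two heavy atoms where bromo has no acceptor and one heavy atom, while the change at the carbonyl carbon stays the larger one, with an 11-fold lower number from compound 1 to compound 4 (1.06 log units; beyond the scatter) and the ring substituent changing along with the chain in that step. No supporting data bear on why this ring position tolerates these exchanges.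

From the compounds shown here alone, whether the same flat reading extends to groups of another kind at this position, such as an amine, a carboxylic acid or a longer alkoxy chain, stays open. Also open, going by these compounds, is how trifluoromethyl, the ring group of compound 1, would read on the urea, which would separate the contribution of the ring group from that of the group on the carbonyl carbon.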